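This account rests on a few compounds, and the source may have more. Where it says the series, first, only, none or still open, it means among the compounds named here.

Three compounds that share one core and differ only in the group on a saturated chain carbon have been measured in a functional assay on P388 cells (Mus musculus) for cytotoxicity; a higher number here means a weaker inhibitor, a lower number a stronger inhibitor. Compound 2 `Cc1cc(-c2c(F)cc3c(=O)c(Cc4ccccc4)cn(C4CC4)c3c2F)cc(C)n1`, which carries a plain phenyl there, gives 7300 nM, the highest number of the three and so the weakest inhibitor among them. Compound 1 `Cc1cc(-c2c(F)cc3c(=O)c(Cc4ccc[nH]4)cn(C4CC4)c3c2F)cc(C)n1`, with 1H-pyrrol-2-yl in that place, gives 930 nM, and compound 3 `Cc1cc(-c2c(F)cc3c(=O)c(Cc4ccc(O)cc4O)cn(C4CC4)c3c2F)cc(C)n1`, with 2,4-dihydroxyphenyl, gives 210 nM.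

Compound 4 `Cc1cc(-c2c(F)cc3c(=O)c(Cc4ccc(O)cc4)cn(C4CC4)c3c2F)cc(C)n1` has not yet been measured. It differs from compound 2 by one small edit: hydroxy in place of hydrogen on an aromatic carbon, para to a large group, which turns phenyl into 4-hydroxyphenyl.

The most relevant measured step is the large one, a 35-fold lower number from compound 2 to compound 3 (1.54 log units; beyond the scatter). The 2,4-dihydroxyphenyl of compound 3 contains the 4-hydroxyphenyl of compound 4 with a further hydroxy added, so that step shows both edits together, and the data do not say how it divides between them. Going by the values given here, the modest steps of a 7.8-fold higher number from compound 1 to compound 2 (0.89 log units; beyond the scatter) and a 4.4-fold lower number from compound 1 to compound 3 (0.65 log units; beyond the scatter) show only that this group matters in this assay. A lower number than for compound 2 is therefore expected, covering part of that large step. The expected step is a 5.6-fold lower number from compound 2 to compound 4 (0.75 log units; beyond the scatter). For compound 4 the estimate is 1300 nM, with an expected range of 300 nM to 5000 nM.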

Compound 4, half-maximal inhibitory concentration: 1500 nM
Compound 4: the middle estimate sits 1.2-fold (0.06 log units) below what was measured; measured number inside the range.
By their numbers in this assay, from the lowest: compound 3; then compounds 1 and 4 (each within the scatter of the next); then compound 2.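

In this assay, a single hydroxy on the benzyl ring is enough to move the number, with a 4.9-fold lower number from compound 2 to compound 4 (0.69 log units; beyond the scatter), so the earlier large gain from phenyl to 2,4-dihydroxyphenyl does not depend on having both hydroxy groups. The second hydroxy still adds to it, since removing that group gives a 7.1-fold higher number from compound 3 to compound 4 (0.85 log units; beyond the scatter), and both of these steps lie beyond the usual scatter, so each hydroxy of 2,4-dihydroxyphenyl goes with a real change in this series. The new result also links two different groups, because 4-hydroxyphenyl and 1H-pyrrol-2-yl, with a 1.6-fold higher number from compound 1 to compound 4 (0.21 log units; within the scatter), cannot be told apart in this assay, as that step lies within the scatter.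

The compounds shown leave open whether the other hydroxy of 2,4-dihydroxyphenyl would have an effect on its own without the one in compound 4, and whether a methoxy, an amine or a carboxylic acid in place of that hydroxy would also give a lower number than phenyl. Nothing available here offers an explanation for why adding a hydroxy changes the number in these cells.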